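The source may report more compounds than this note shows. Statements on the series, on what has been measured and on what is new or still open speak of the compounds shown alone.

Compound 1 `COc1ccc(C(=O)Nc2nnc(/C=C/c3cc(OC)c(OC)c(OC)c3Br)s2)cc1`: 220 nM
Compound 2 `COc1cc(/C=C/c2nnc(NC(=O)c3cccc(O)c3)s2)cc(OC)c1OC`: 260 nM

In a functional assay on HepG2 cells (Mus musculus) for antiproliferative activity against HepG2 (Homo sapiens), read by MTT assay, with a stated time of 48 h (on this read-out higher numbers stand for weaker inhibition and lower numbers for stronger inhibition), compound 1 gives 220 nM. Among the compounds with values here, that places it within the usual scatter of compound 2 at 260 nM, so the two cannot be ranked, and both sit at the same level on the numbers so far.

Compound 3 `COc1cc(/C=C/c2nnc(NC(=O)c3ccccc3)s2)c(Br)c(OC)c1OC` keeps the rest of compound 1 but has hydrogen in place of methoxy on an aromatic carbon, turning 4-methoxyphenyl into phenyl: hydrogen in place of methoxy on an aromatic carbon. Within the data shown here, no measured pair isolates this change, so the evidence is thin. Compound 2 also has no 4-methoxyphenyl and gives 260 nM, but it differs from compound 1 in other places too. In this assay, no shift beyond the scatter is expected, in either direction. The estimated step of a 1.4-fold higher number from compound 1 to compound 3 (0.13 log units; within the scatter) is therefore small. For compound 3 the expected value is 300 nM, with an estimated range of 100 nM to 900 nM.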

Compound 3, half-maximal inhibitory concentration: 180 nM
The estimate for compound 3 lay 1.7-fold (0.22 log units) above the measured number; low and high end bracket the measured number.
By their numbers in this assay, from the lowest: compounds 3, 1 and 2 (each within the scatter of the next).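

In this assay, replacing the methoxy group with hydrogen, which turns 4-methoxyphenyl into phenyl, gives a 1.2-fold lower number from compound 1 to compound 3 (0.09 log units; within the scatter) and so stays within the scatter. This is the first pair shown that differs only at this position, on an aromatic carbon para to a large group, and it shows that the methoxy group is not required to keep the number at the level of compound 1 in this assay. Nothing measured here offers an explanation for this result.

Going by these compounds, whether an amine, a carboxylic acid or a longer chain at this same place would also leave the number level stays open. No pair shown isolates the bromine of compound 1 either, so what that atom contributes cannot be read from these compounds.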